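This account rests on a few compounds, and the source may have more. Where it says the series, first, only, none or still open, it means among the compounds named here.

Compound 1 `Fc1ccccc1Nc1nc2nonc2nc1Nc1ccccc1` and compound 2 `Cc1ccccc1Nc1nc2nonc2nc1Nc1ccccc1F` share a core and have both been tested in an assay on mitochondria from L6 cells (Rattus norvegicus) for activation, with a stated time of 90 min; on this read-out lower numbers stand for an effect already at smaller amounts and higher numbers for an effect only at larger amounts of compound. In this assay compound 1 gives 2200 nM, and compound 2 gives 1100 nM. Within the data shown here, the one step between them, a 2.0-fold lower number from compound 1 to compound 2 (0.30 log units; within the scatter), so compound 2 stands at the lower of the two numbers only nominally, its distance to compound 1 being within the scatter. Compound 3 `Fc1ccccc1Nc1nc2nonc2nc1Nc1ccccc1OC(F)(F)F` differs from compound 2 by trifluoromethoxy in place of methyl on an aromatic carbon. Among the measured compounds shown here, no measured step concerns a trifluoromethoxy group; the only step at hand, a 2.0-fold lower number from compound 1 to compound 2 (0.30 log units; within the scatter), dealt with a different exchange and stayed within the scatter, so it offers no direction for this change. For compound 3 the expected step is therefore a 1.1-fold higher number from compound 2 to compound 3 (0.04 log units; within the scatter), with no movement beyond the scatter anticipated. Compound 3 is accordingly estimated at 1200 nM, within a range from 400 nM to 3500 nM.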

Compound 3, half-maximal effective concentration: 1700 nM
Beside the measured number, compound 3's estimate is 1.4-fold (0.15 log units) below it, and the stated range covers the measured number.
By their numbers in this assay, from the lowest: compounds 2, 3 and 1 (each within the scatter of the next).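

At this place on the aromatic ring, ortho to a large group, trifluoromethoxy with its 5 heavy atoms takes the place of methyl with its 1 in this assay, giving a 1.5-fold higher number from compound 2 to compound 3 (0.19 log units; within the scatter), and set against hydrogen the same group gives a 1.3-fold lower number from compound 1 to compound 3 (0.11 log units; within the scatter). Hydrogen, methyl and trifluoromethoxy at this place thus all lie within the scatter of one another, so a much bigger group here, one that also brings a hydrogen-bond acceptor, has not moved the number beyond the scatter. No evidence is at hand that would account for this result.

Going by these compounds, whether an amine, a carboxylic acid or a longer chain at this place would move the number beyond the scatter stays open. Also open, on these data alone, is whether these exchanges would read the same if the fluorine on the other aromatic ring were replaced.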